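Hydroxy added to compound 2: working notes

The source may hold more compounds than are shown below. What is called first, only, known or untested is meant among the compounds shown, and "the series" means these compounds.

Measured in a functional assay on DU-145 cells (Homo sapiens) for inhibition, read by MTT assay, with a stated time of 72 h; a higher number here means a weaker inhibitor, a lower number a stronger inhibitor:
- compound 1 `O=C1C=C(N2CCC(c3ccccc3)CC2)C(=O)c2c(O)cccc21`: 3000 nM
- compound 2 `Cc1ccccc1C1CCN(C2=CC(=O)c3ccccc3C2=O)CC1`: 6100 nM

Of the two measured compounds, compound 2 has the higher number at 6100 nM, so it is the weaker inhibitor, and its gap to compound 1 lies just beyond the scatter. Not yet measured in this assay is compound 3 `Cc1ccccc1C1CCN(C2=CC(=O)c3cccc(O)c3C2=O)CC1`, which has hydroxy in place of hydrogen on an aromatic carbon of compound 2: hydroxy in place of hydrogen on an aromatic carbon. Among the compounds with values here, no measured pair isolates this change. Compound 1, at 3000 nM, also carries a hydroxy but differs from compound 2 in a second place, so it offers only weak support. The expected change is a 1.7-fold lower number from compound 2 to compound 3 (0.24 log units; within the scatter), a small move towards a lower number that may not exceed the scatter. For compound 3 the estimated value is 3500 nM, with an expected range of 1200 nM to 9000 nM.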

Compound 3, half-maximal inhibitory concentration: 2500 nM
For compound 3 the middle estimate is 1.4-fold (0.15 log units) above the measured one; low and high end bracket the measured number.
By their numbers in this assay, from the lowest: compounds 3 and 1 (each within the scatter of the next); then compound 2.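

In this assay, within the data shown here, hydroxy in place of hydrogen on an aromatic carbon now has a direct single-change comparison, which the earlier compounds lacked: it gives a 2.4-fold lower number from compound 2 to compound 3 (0.39 log units; beyond the scatter), a modest step that lies beyond the scatter. Methyl in place of hydrogen on an aromatic carbon, read with the hydroxy present, gives a 1.2-fold lower number from compound 1 to compound 3 (0.08 log units; within the scatter) and stays within the scatter, so this methyl shows no readable effect in that setting. Nothing available here bears on the reason for either step.

Whether this step is specific to hydroxy remains open, since methoxy, fluorine and an amine at the same place are not among the compounds shown. Among these compounds, also open is how the methyl behaves without the hydroxy, as no single-change pair covers that comparison.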